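Methyl branch on the side chain of compound 3

The compounds below may be only part of what the source reports. "The series", "measured", "known", "first", "only" and "open" are said of these compounds alone.

Compound 1 `CC/C=C\C[C@H]1C(=O)C=C[C@H]1CC(=O)OCC`: 20000 nM
Compound 2 `CC/C=C\C[C@H]1C(=O)C=C[C@H]1CC(=O)OCCO`: 24000 nM
Compound 3 `CC/C=C\C[C@H]1C(=O)C=C[C@H]1CC(=O)OCCOC`: 27000 nM

All three values come from a functional assay on RAW264.7 cells (Mus musculus) for inhibition, read by ELISA, with a stated time of 24 h; on this read-out lower numbers stand for an effect already at smaller amounts and higher numbers for an effect only at larger amounts of compound. Compound 3 cannot be told apart from the other two, as the steps to it are a 1.4-fold higher number from compound 1 to compound 3 (0.13 log units; within the scatter) and a 1.1-fold higher number from compound 2 to compound 3 (0.05 log units; within the scatter). Compound 4 `CC/C=C\C[C@H]1C(=O)C=C[C@H]1CC(=O)OC(C)COC` differs from compound 3 by methyl in place of hydrogen on a saturated chain carbon bound to an oxygen next to a carbonyl group and a saturated chain carbon, so 2-methoxyethyl becomes 1-(methoxymethyl)ethyl. Within the data shown here, no measured step puts a methyl on this carbon, so the evidence is indirect. The other change on this chain, a 1.2-fold higher number from compound 1 to compound 2 (0.08 log units; within the scatter), was equally small. No step beyond the scatter is therefore expected in this assay. The estimated step is no change at the digits printed from compound 3 to compound 4 (within the scatter). For compound 4 the estimated value is 27000 nM, with an expected range from 14000 nM to 50000 nM.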

Compound 4, half-maximal effective concentration: 23000 nM
Estimate against measurement, compound 4: 1.2-fold (0.07 log units) above; measured number inside the range.
By their numbers in this assay, from the lowest: compounds 1, 4, 2 and 3 (each within the scatter of the next).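

In this assay, methyl in place of hydrogen on this saturated chain carbon bound to an oxygen next to a carbonyl group gives a 1.2-fold lower number from compound 3 to compound 4 (0.07 log units; within the scatter), so a branch here does not take the number outside the scatter. The branched 1-(methoxymethyl)ethyl group also stays within the scatter of the unbranched compounds, with a 1.0-fold lower number from compound 2 to compound 4 (0.02 log units; within the scatter) and a 1.2-fold higher number from compound 1 to compound 4 (0.06 log units; within the scatter). No measurement shown here offers an explanation for this result. The compounds shown leave open whether an amine, a carboxylic acid or a much longer chain at this ester oxygen would give a step beyond the scatter.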